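This account rests on a few compounds, and the source may have more. Where it says the series, first, only, none or still open, it means among the compounds named here.

In a functional assay on A549 cells (Homo sapiens) for inhibition, read by MTT assay, with a stated time of 48 h (a higher number here means a weaker inhibitor, a lower number a stronger inhibitor), compound 1 `COc1ccc(C(c2c[nH]c3ccc(Br)cc23)c2c[nH]c3ccc(Br)cc23)c(OC)c1` gives 100000 nM. Compound 2 `O=[N+]([O-])c1ccc2[nH]cc(C(c3ccc(Br)cc3)c3c[nH]c4ccc([N+](=O)[O-])cc34)c2c1` has no number of its own, only a limit of the assay, > 100000 nM. Compound 3 `CCCCCCCC(c1c[nH]c2ccc([N+](=O)[O-])cc12)c1c[nH]c2ccc([N+](=O)[O-])cc12` keeps the rest of compound 2 but carries heptyl in place of 4-bromophenyl on a saturated chain carbon bound to two aromatic carbons. Going by the values given here, no measured pair shows what such a change does, so no shift beyond the usual scatter is expected in this assay. The expected at least 1.2-fold lower number from compound 2 to compound 3 (0.09 log units; that floor lies within the scatter) is an estimate only. For compound 3 the estimated value is 80000 nM, with an expected range of 25000 nM to 200000 nM.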

Compound 3, half-maximal inhibitory concentration: 12500 nM
Estimate against measurement, compound 3: 6.4-fold (0.81 log units) above; measured number outside the range, below it.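

In this assay, the group on the saturated chain carbon bound to two aromatic carbons proves able to move the result: heptyl in place of 4-bromophenyl gives an at least 8.0-fold lower number from compound 2 to compound 3 (0.90 log units; beyond the scatter). A ring at this place is therefore not required for a measurable number, at least on the core of compound 3. The size of the step remains only a floor, because compound 2 stands at a limit of the assay: the limit of > 100000 nM in this assay, at which 1 of the 3 values shown sits.

Going by these compounds, whether a longer chain, a shorter chain or an amine at this place would lower the number further remains open. So does whether heptyl would have the same effect on the core of compound 1.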